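Series notes: amide epimer of compound 1

This account rests on a few compounds, and the source may have more. Where it says the series, first, only, none or still open, it means among the compounds named here.

Measured compounds
- compound 1, `CC[C@H]1c2cc(Cl)ccc2C(=O)N1c1cncc2c1CCC[C@H]2NC(C)=O`: 97 nM
- compound 2, `CC1(C)c2cc(Cl)ccc2C(=O)N1c1cncc(OC2CN(C(=O)c3ncccc3Cl)C2)c1`: 5 nM
- compound 3, `CCC(=O)N[C@@H]1CCCc2c1cncc2N1C(=O)c2ccc(Cl)cc2[C@@H]1CC`: 12 nM

In an assay on cells for inhibition of cytochrome P450 11B2, mitochondrial (Homo sapiens), read by HTRF (on this read-out higher numbers stand for weaker inhibition and lower numbers for stronger inhibition), compound 1 gives the highest number of the three measured compounds; compound 3 gives a lower number, and compound 2 the lowest.

The unmeasured compound 4, `CC[C@@H]1c2cc(Cl)ccc2C(=O)N1c1cncc2c1CCC[C@H]2NC(C)=O`, differs from compound 1 as follows: the two compounds have the same atoms and bonds and differ only in configuration as drawn: 1 of 2 stereo elements differ; a stereocentre at a saturated ring carbon is drawn S in compound 1 and R in compound 4.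

Going by the values given here, the one single-point step measured, an 8.1-fold lower number from compound 1 to compound 3 (0.91 log units; beyond the scatter), concerns a change on the amide chain and says nothing about configuration at the ring carbon. Among the compounds with values here, no measured pair differs only in configuration, so the direction of this step cannot be read from the data; inverting a stereocentre can shift the number either way, often well beyond the scatter.

Compound 4 is therefore estimated at 120 nM, range 15 nM to 1000 nM, with the expected step of a 1.2-fold higher number from compound 1 to compound 4 (0.09 log units; within the scatter) carrying low confidence in either direction.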

Compound 4, half-maximal inhibitory concentration: 7 nM
Beside the measured number, compound 4's estimate is 17-fold (1.23 log units) above it; the measured number lies below the stated range.
By their numbers in this assay, from the lowest: compounds 2, 4 and 3 (each within the scatter of the next, the first and the last beyond it); then compound 1.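

In this assay, inverting this one saturated ring carbon gives a 14-fold lower number from compound 1 to compound 4 (1.14 log units; beyond the scatter), so configuration at this position carries a large effect by itself, which the amide chain step could not show. The R drawing is the favoured one here, with the second stereo element held constant. The whole step can be assigned to this single stereocentre: the fact that compounds 1 and 4 differ only in the configuration as drawn

Open, on these data alone, is whether the R configuration keeps its advantage with a longer chain on the amide carbonyl, or with an amine in place of the amide. As far as these compounds go, the role of the second stereo element also remains open.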